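The source may report more compounds than this note shows. Statements on the series, on what has been measured and on what is new or still open speak of the compounds shown alone.

In an assay on isolated protein for inhibition of serine/threonine-protein kinase PAK 4 (Homo sapiens), read by filter binding, with a stated time of 20 min, tested at 2 uM (on this read-out lower numbers stand for less inhibition and higher numbers for more inhibition at the one concentration tested (going by the name of the read-out)), compound 1 `OCC(O)CNc1nc(Nc2ccccc2)nc2[nH]ccc12` gives 82.4%. Compound 2 `N[C@H]1CCCN(c2nc(Nc3cccc(Cl)c3)nc3[nH]ccc23)C1` gives 38.3%, and compound 3 `N[C@@H]1CCCN(c2nc(Nc3cccc(Cl)c3)nc3[nH]ccc23)C1` gives 72.5%. Among the measured compounds shown here, the step of a number 34.2 percentage points higher from compound 2 to compound 3 (beyond the scatter) is the one measured change, and it turns on (the fact that compounds 2 and 3 differ only in the configuration as drawn). On these numbers compound 3 stands second highest of the three: compound 1 sits higher, within the scatter, while compound 2 sits lower, beyond it.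

Compound 4 `NCC1CCCN(c2nc(Nc3cccc(Cl)c3)nc3[nH]ccc23)C1` is the next case: 3-(aminomethyl)piperidin-1-yl in place of 3-aminopiperidin-1-yl on an aromatic carbon. For the measured compounds named here, the only measured step that bears on this change is the configurational one from compound 2 to compound 3, which was large. The entering group in compound 4 carries no defined stereocentre, so that step gives no clear direction for the present change, only a sign that this part of the molecule moves the read-out strongly. Compound 4 is therefore expected to land between the two configurational isomers, the step of a number 17.5 percentage points lower from compound 3 to compound 4 (beyond the scatter) being an expected decrease. The estimate for compound 4 is 55%, within a range from 25% to 85%.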

Compound 4, a percentage reported as inhibition, at one concentration (the size of the read-out at that concentration, not a potency): 61%
The estimate for compound 4 lay 6 percentage points below the measured number; low and high end bracket the measured number.
By their numbers in this assay, from the lowest: compound 2; then compound 4; then compounds 3 and 1 (each within the scatter of the next).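

In this assay, the change from 3-aminopiperidin-1-yl to 3-(aminomethyl)piperidin-1-yl reads two ways, since the leaving group exists here in two configurations: the step is a number 11.5 percentage points lower from compound 3 to compound 4 (beyond the scatter) against one isomer and a number 22.7 percentage points higher from compound 2 to compound 4 (beyond the scatter) against the other. Both steps lie beyond the scatter, so this aromatic carbon accepts the entering group with a read-out distinct from either isomer, and the direction of the change depends on the isomer taken as reference. The wider spread remains the one within the 3-aminopiperidin-1-yl pair, whose members stand apart on one feature alone: the fact that compounds 2 and 3 differ only in the configuration as drawn

Going by these compounds, whether single configurations of 3-(aminomethyl)piperidin-1-yl would separate as compounds 2 and 3 do stays open. Also open, on these data alone, is what a 3-hydroxypiperidin-1-yl group or a longer 3-(2-aminoethyl)piperidin-1-yl chain would give at this carbon.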